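Vero cytotoxicity in a coumarin amino-alcohol series: compound 4

The source may hold more compounds than are shown below. What is called first, only, known or untested is meant among the compounds shown, and "the series" means these compounds.

Working notes on the series. In an ADME assay on Vero cells (Chlorocebus sabaeus) for cytotoxicity, read by fluorescence and resazurin assay, with a stated time of 72 h (on this read-out lower numbers stand for higher toxicity in this test and higher numbers for lower toxicity in this test), compound 1 `O=c1cc(OCC(O)CNC2CCCCC2)c2ccccc2o1` gives only a limit, > 100000 nM. Compound 3 `CCCCCCCC/C=C/CCCCCCCCNCC(O)COc1cc(=O)oc2ccccc12` likewise reports only a limit in this assay, > 100000 nM. For compound 2 `O=C(O)CCCNCC(O)COc1cc(=O)oc2ccccc12` the result in this assay is "not determined" (no result reported), so compound 2 stands on no single number; what can be said rests on (the limit of > 100000 nM in this assay, at which 2 of the 3 values shown sit).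

Compound 4 `O=c1cc(OCC(O)CNC2CC2)c2ccccc2o1` differs from compound 2 by cyclopropyl in place of 3-carboxypropyl on an amine nitrogen. Among the measured compounds shown here, no measured step covers this change. Given that the two measured neighbours sit at the limit of > 100000 nM in this assay, at which 2 of the 3 values shown sit, no step beyond the scatter is expected for compound 4 in this assay, in either direction. Compound 4 is estimated to give 100000 nM in this assay, with a range from 30000 nM to 300000 nM, most likely reported again as a limit.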

Compound 4, half-maximal cytotoxic concentration: > 100000 nM
Compound 4: only a limit was reported; the forecaster's own chance of this, stated with the estimate: 80%; the middle value lies on the limit itself.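

Compound 1 and compound 4 both report only a limit in this assay, and the step between them cannot be read. The compounds shown leave open whether any substituent on this amine nitrogen gives a measurable cytotoxic concentration in this assay.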